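Swapping an amide side chain in a vitamin D receptor series

This account rests on a few compounds, and the source may have more. Where it says the series, first, only, none or still open, it means among the compounds named here.

Compound 2 `CCn1c(C(=O)NCCN(C)C)ccc1C(CC)(CC)c1ccc(OCC(O)C(C)(C)C)c(C)c1` gives 14 nM in an assay on HL-60 cells for agonist activity at vitamin D3 receptor (Homo sapiens), read by microscopy, with a stated time of 96 h (a lower number here means that less compound is needed, a higher number that more compound is needed for the effect), the lowest of the two numbers measured here. The nearest measured neighbour is compound 3 `CCn1c(C(=O)N(C)CC(=O)O)ccc1C(CC)(CC)c1ccc(OCC(=O)C(C)(C)C)c(C)c1`, which gives 1390 nM. Compound 1 `CCOC(=O)CN(C)C(=O)c1ccc(C(CC)(CC)c2ccc(OCC(=O)C(C)(C)C)c(C)c2)n1CC` gives only a limit, > 50000 nM, so no number is known for it (the limit of > 50000 nM in this assay, at which 1 of the 3 values shown sits). For the measured compounds named here, the one measured step, an at least 35-fold lower number from compound 1 to compound 3 (1.55 log units; beyond the scatter), lies on the carbonyl-bearing side group, where hydrogen in place of ethyl makes the number drop sharply.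

Compound 4 `CCn1c(C(=O)Nc2ccc(OC(F)(F)F)cc2)ccc1C(CC)(CC)c1ccc(OCC(O)C(C)(C)C)c(C)c1` differs from compound 2 at a different place, the amide-type nitrogen: 4-(trifluoromethoxy)phenyl in place of 2-(dimethylamino)ethyl on an amide-type nitrogen. Going by the values given here, no measured step touches this part of the molecule, so the step from compound 1 to compound 3 gives no direct guidance on direction or size, and the expectation rests on compound 2 alone as the starting point. A change of this size at an amide-type nitrogen could move the number either way, so a modest change in either direction, or none beyond the scatter, is expected.

Compound 4 is therefore expected to give about 30 nM, most likely between 5 nM and 300 nM. That estimate corresponds to an expected step of a 2.1-fold higher number from compound 2 to compound 4 (0.33 log units; beyond the scatter).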

Compound 4, half-maximal effective concentration: > 50000 nM
Compound 4: only a limit was reported; the forecaster's own chance of this, stated with the estimate: 5%; middle value at least 1600-fold (3.22 log units) from the limit.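

In this assay, putting 4-(trifluoromethoxy)phenyl in place of 2-(dimethylamino)ethyl on the amide-type nitrogen gives an at least 3500-fold higher number from compound 2 to compound 4 (3.55 log units; beyond the scatter). For the compounds shown here, compound 4 gives > 50000 nM, which is a limit of the assay and not a number: the limit of > 50000 nM in this assay, at which 2 of the 4 values shown sit. Until now, the only measured step lay on the carbonyl-bearing side group, so this is the first to show that the group on the amide-type nitrogen matters, and that this one change can take a compound from a low number to the limit of the assay.

This single change removes a chain that ends in an amine and brings in a six-membered aromatic ring carrying trifluoromethoxy, so the compounds shown cannot tell which part of the change accounts for the loss. An unsubstituted phenyl on the same nitrogen would test the ring without the trifluoromethoxy group, while a 3-(dimethylamino)propyl chain would show whether a longer chain that keeps the amine holds on to the low number of compound 2.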